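A few compounds are considered here, and "the series" means these few. Any claim that something is new, unique, unknown or untested is made for them only; others in the source may bear on it.

Of the compounds shown here, two sharing one core have so far been measured in a physicochemical assay for pharmacokinetics; a lower number here means that the compound disappears faster, a higher number that the compound lasts longer. Compound 1, `O=C(NCc1ccc(C(F)(F)F)cc1)N1C(=O)c2ccccc2S1(=O)=O`, gives > 166 h in this assay, and this is a limit of the assay rather than a number. Compound 2, `O=C(NCc1ccccc1Br)N1C(=O)c2ccccc2S1(=O)=O`, likewise gives > 166 h in this assay, again a limit and not a number. Compound 2 therefore stands at the limit of > 166 h in this assay, at which 2 of the 2 values shown sit, so the two measured compounds cannot be told apart on the numbers shown. Compound 3, `COc1ccccc1CNC(=O)N1C(=O)c2ccccc2S1(=O)=O`, has not yet been measured. It differs from compound 2 in one place: methoxy in place of bromo on an aromatic carbon. For the measured compounds named here, with both measured values sitting at the limit, no step between measured compounds can be read off. The expected step is a step that the limit leaves unreadable from compound 2 to compound 3, that is, none beyond the scatter, and a result reported only as a limit seems likely. Compound 3 is estimated at 200 h in this assay, within a range from 80 h to 600 h.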

Compound 3, half-life: > 166 h
Compound 3: a limit, no number; the forecaster's own chance of this, stated with the estimate: 75%; the middle value lies beyond the limit too.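

No step can be read from compound 2 to compound 3, since both give only a limit and not a number in this assay: the limit of > 166 h in this assay, at which 3 of the 3 values shown sit.

The compounds shown leave open how long each one actually lasts, and whether exchanging bromo for methoxy changes that at all.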